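The compounds below may be only part of what the source reports. "The series", "measured", "known", "first", "only" and "open" are said of these compounds alone.

Values so far in a functional assay on A-427 cells (Homo sapiens) for cytotoxicity, read by colorimetric assay and MTT assay; on this read-out higher numbers stand for weaker inhibition and lower numbers for stronger inhibition
compound 1 `COc1ccc(-c2cc3c(OC)cc(OC)cc3n(CC#N)c2=O)cc1` gives 10000 nM
compound 2 `COc1ccc(-c2cc3c(OC)cc(OC)cc3n(CC(=O)OCc3ccccc3)c2=O)cc1` gives 10000 nM

Compound 2 stands level with compound 1 at the digits given, so neither ranks ahead of the other. The next entry is compound 3 `COc1ccc(-c2cc3c(OC)cc(OC)cc3n(CCC(=O)OCc3ccccc3)c2=O)cc1`, which has not been measured yet. It carries (benzyloxycarbonyl)methyl in place of benzyloxycarbonyl on a saturated chain carbon bound to an aromatic nitrogen. Among the compounds with values here, the only measured step at this place, starting from compound 1 (no change at the digits printed from compound 1 to compound 2 (within the scatter)), stayed within the scatter, so no step beyond the scatter is expected in this assay and no direction can be argued. That is a single step, and it is thin ground for any forecast. The estimated step therefore stays small (a 1.1-fold lower number from compound 2 to compound 3 (0.05 log units; within the scatter)). Compound 3 is expected at 9000 nM with an estimated range from 4000 nM to 20000 nM on this read-out.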

Compound 3, half-maximal inhibitory concentration: 10000 nM
For compound 3 the middle estimate is 1.1-fold (0.05 log units) below the measured one, and the stated range covers the measured number.
By their numbers in this assay, from the lowest: compounds 1, 2 and 3 (each within the scatter of the next).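

In this assay, putting (benzyloxycarbonyl)methyl in place of benzyloxycarbonyl on a saturated chain carbon bound to an aromatic nitrogen gives no change at the digits printed from compound 2 to compound 3 (within the scatter), so extending the chain at this place does not separate the two esters on this read-out. The comparison with the nitrile gives no change at the digits printed from compound 1 to compound 3 (within the scatter), which shows that this longer ester also cannot be told apart from the cyano-bearing substituent, with compound 3 at 10000 nM. No measured evidence is available to explain this flat result.

The three compounds show no step beyond the scatter at this place, so they do not identify any feature of the substituent that moves the cytotoxicity read-out. On these data alone, whether a free carboxylic acid, a primary amine or a still longer chain ending in the benzyl ester would give a different number on the shared core remains open.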